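Heteroaryl carboxamide in place of fluorophenyl on the shared core

A few compounds are considered here, and "the series" means these few. Any claim that something is new, unique, unknown or untested is made for them only; others in the source may bear on it.

The series keeps the core of compound 1 `O=C(CCCCCCc1ccccc1)c1ncc(-c2ccc(F)cc2)o1` and varies the aromatic group attached to it. For the measured compounds named here, in an assay (Rattus norvegicus) for inhibition of Fatty-acid amide hydrolase 1 (Homo sapiens) (a lower number here means a stronger inhibitor, a higher number a weaker inhibitor), compound 1 gives 62 nM, the second highest of the three numbers known so far. Compound 2 `NS(=O)(=O)c1ccc(-c2cnc(C(=O)CCCCCCc3ccccc3)o2)cc1` gives 10 nM in this assay, and compound 3 `O=C(CCCCCCc1ccccc1)c1ncc(-c2ccc(C(=O)C(F)(F)F)cc2)o1` gives 65 nM.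

The next compound, compound 4 `NC(=O)c1cccc(-c2cnc(C(=O)CCCCCCc3ccccc3)o2)n1`, differs from compound 1 in one place: 6-carbamoylpyridin-2-yl in place of 4-fluorophenyl on an aromatic carbon. Going by the values given here, two measured steps bear on this change. The first is a 6.2-fold lower number from compound 1 to compound 2 (0.79 log units; beyond the scatter), where a sulfamoyl group entered. The second is a 1.0-fold higher number from compound 1 to compound 3 (0.02 log units; within the scatter), where a (trifluoromethyl)carbonyl group entered. Among the compounds with values here, the entering group of compound 4 carries 1 hydrogen-bond donor and 2 hydrogen-bond acceptors, so the sulfamoyl step is the closer parallel, although here the carbamoyl group sits on a pyridin-2-yl ring rather than on the ring that bore the sulfamoyl group, and no measured step covers that ring exchange. A step toward a lower number, somewhat smaller than the sulfamoyl step, is therefore expected: a 3.1-fold lower number from compound 1 to compound 4 (0.49 log units; beyond the scatter). Compound 4 is accordingly estimated at 20 nM, with a range from 7 nM to 60 nM.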

Compound 4, inhibition constant: 1 nM
Estimate against measurement, compound 4: 20-fold (1.30 log units) above, outside the stated range (below it).
By their numbers in this assay, from the lowest: compound 4; then compound 2; then compounds 1 and 3 (each within the scatter of the next).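

In this assay, replacing 4-fluorophenyl with 6-carbamoylpyridin-2-yl on the aromatic carbon next to the ring oxygen gives a 62-fold lower number from compound 1 to compound 4 (1.79 log units; beyond the scatter), a larger step at this position than a 6.2-fold lower number from compound 1 to compound 2 (0.79 log units; beyond the scatter), and it places compound 4 lowest in the series, ahead of compound 2 at 10 nM. The earlier compounds shown here changed only the group on a retained ring, whereas this step shows that the position tolerates a change of the aromatic ring and its substituent together, and that such a combined change can lower the number well past the sulfamoyl result. The ring exchange and the carbamoyl group entered in a single step, so their shares cannot be separated, and no measurement available here accounts for the size of the step.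

An unsubstituted pyridin-2-yl group and a carbamoylphenyl group would divide the step between the ring nitrogen and the carbamoyl group. A carboxylic acid or a nitrile in place of the carbamoyl group on the same pyridine ring would test how far the result depends on the amide itself.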